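The source may hold more compounds than are shown below. What is called first, only, known or untested is meant among the compounds shown, and "the series" means these compounds.

Among the compounds with values here, in a functional assay on HT-29 cells (Homo sapiens) for inhibition, read by MTT assay, with a stated time of 48 h (a lower number here means a stronger inhibitor, a higher number a weaker inhibitor), compound 2 `Cc1ccc(NC(=O)NC(=O)c2ccc(OCc3cccc(Cl)c3Cl)cc2)cc1-c1nc2ccccc2[nH]1` gives 48500 nM, the higher of the two numbers so far. Compound 1 `Cc1ccc(NC(=O)NC(=O)c2ccc(OCc3ccccc3F)cc2)cc1-c1nc2ccccc2[nH]1` gives 760 nM in this assay. Compound 3 `Cc1ccc(NC(=O)NC(=O)c2ccc(OCc3ccc(F)cc3)cc2)cc1-c1nc2ccccc2[nH]1` carries 4-fluorophenyl in place of 2,3-dichlorophenyl on a saturated chain carbon bound to an oxygen on an aromatic ring. Within the data shown here, the only step bearing on this is a 64-fold higher number from compound 1 to compound 2 (1.80 log units; beyond the scatter), which runs the reverse way on the same carbon, from a monofluorophenyl to the dichlorophenyl. Going back to a monofluorophenyl, here 4-fluorophenyl rather than the 2-fluorophenyl of compound 1, the expected step for compound 3 is a large fall, a 32-fold lower number from compound 2 to compound 3 (1.51 log units; beyond the scatter). Compound 3 is therefore estimated at 1500 nM, between 400 nM and 8000 nM.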

Compound 3, half-maximal inhibitory concentration: 980 nM
Compound 3: the middle estimate sits 1.5-fold (0.18 log units) above what was measured, and the stated range covers the measured number.
By their numbers in this assay, from the lowest: compounds 1 and 3 (each within the scatter of the next); then compound 2.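

In this assay, the step of a 49-fold lower number from compound 2 to compound 3 (1.69 log units; beyond the scatter) shows that a fluorophenyl with its fluorine placed differently also escapes the high number of the 2,3-dichlorophenyl compound. The step of a 1.3-fold higher number from compound 1 to compound 3 (0.11 log units; within the scatter) shows that 4-fluorophenyl and 2-fluorophenyl do not separate at this place, so the large step belongs to the change away from 2,3-dichlorophenyl and not to one particular fluorophenyl. No measurement at hand accounts for that large step.

Still open, from the compounds shown here alone, is whether a single chlorine on this phenyl would already give the high number or whether both chlorines of 2,3-dichlorophenyl are needed. Going by these compounds, how an unsubstituted phenyl or a methoxyphenyl would read at this place also remains open.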